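Fluoro on the Benzyl Ring: Two Cores, One Change

A few compounds are considered here, and "the series" means these few. Any claim that something is new, unique, unknown or untested is made for them only; others in the source may bear on it.

In an assay on isolated protein for inhibition of thyroid hormone receptor beta (Homo sapiens), read by fluorescence polarization (on this read-out higher numbers stand for weaker inhibition and lower numbers for stronger inhibition), compound 1 `CN(Cc1ccccc1)C(=O)C1CCN(C(=O)c2ccc(S(C)(=O)=O)c([N+](=O)[O-])c2)CC1` gives > 60000 nM, a limit of the assay.
Compound 2 `CN(Cc1ccccc1F)C(=O)C1CCN(C(=O)c2ccc(S(C)(=O)=O)c([N+](=O)[O-])c2)CC1` gives > 60000 nM, also a limit of the assay.
Among the compounds with values here, compound 3 `CN(Cc1ccccc1)C(=O)CNC(=O)c1ccc(S(C)(=O)=O)c([N+](=O)[O-])c1` gives 39000 nM, the only number in the set.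

The change from compound 1 to compound 2 is fluoro in place of hydrogen on an aromatic carbon. Its step that the two limits leave unreadable from compound 1 to compound 2 cannot be read because both values sit at the limit of > 60000 nM in this assay, at which 2 of the 3 values shown sit. Compound 4 `CN(Cc1cccc(F)c1)C(=O)CNC(=O)c1ccc(S(C)(=O)=O)c([N+](=O)[O-])c1` carries the same kind of change against compound 3, (fluoro in place of hydrogen on an aromatic carbon), but not the same change: the fluoro enters ortho to a large group in compound 2 and meta to a large group in compound 4. The difference between the two cores is not broken down here.

With the earlier step unreadable, the step from compound 3 to compound 4 in this assay is expected to be small, a 1.1-fold lower number from compound 3 to compound 4 (0.05 log units; within the scatter), resting only on compound 3 at 39000 nM. Compound 4 is estimated at 35000 nM, between 15000 nM and 80000 nM.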

Compound 4, half-maximal inhibitory concentration: > 60000 nM
Compound 4: a limit, no number; the forecaster's own chance of this, stated with the estimate: 30%; middle value at least 1.7-fold (0.23 log units) from the limit.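

Compound 4 gives > 60000 nM, a limit of the assay. In this assay, on these data alone, benzyl to 3-fluorobenzyl on the core of compound 3 gives an at least 1.5-fold higher number from compound 3 to compound 4 (0.18 log units; that floor lies within the scatter), so the change shows no shift beyond the scatter, and its true size stays unknown. The step on the core of compound 1 cannot be read, and whether the change carries from one core to the other is not shown, because both of its values sit at a limit: the limit of > 60000 nM in this assay, at which 3 of the 4 values shown sit.

The compounds shown leave open whether any group on the benzyl ring gives a number clear of this limit. An amine or a carboxylic acid on that ring, or a longer chain in the link of compound 3, remains an open case.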